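Two amides at the assay limit, and a biphenyl successor

The compounds below may be only part of what the source reports. "The series", "measured", "known", "first", "only" and "open" are said of these compounds alone.

Measured so far in an assay on isolated protein for inhibition of receptor-type tyrosine-protein phosphatase C (Homo sapiens), read by spectrophotometry; a higher number here means a weaker inhibitor, a lower number a stronger inhibitor:
compound 1 `CCCNC(=O)COc1ccc2cc(C(O)(C(F)(F)F)C(F)(F)F)c(O)cc2c1` — > 20000 nM
compound 2 `O=C(COc1ccc2cc(C(O)(C(F)(F)F)C(F)(F)F)c(O)cc2c1)NCc1ccc(F)cc1` — > 20000 nM

Compound 1 gives > 20000 nM in this assay, and that figure is a limit of the assay, not a number. Compound 2 gives > 20000 nM in this assay, again a limit rather than a number. Among the compounds with values here, the only measured step, a step that the two limits leave unreadable from compound 1 to compound 2, therefore cannot be sized, because the limit of > 20000 nM in this assay, at which 2 of the 2 values shown sit, is where both values sit.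

Compound 3 `O=C(COc1ccc2cc(C(O)(C(F)(F)F)C(F)(F)F)c(O)cc2c1)Nc1ccc(-c2ccccc2)cc1` differs from compound 2 by 4-phenylphenyl in place of 4-fluorobenzyl on an amide-type nitrogen. Within the data shown here, no measured step reads on this change, since the single step between compound 1 and compound 2 is unreadable, so there is no ground to expect a move beyond the scatter in either direction. Compound 3 is expected to give 25000 nM in this assay, with a range from 8000 nM to 60000 nM. The step that the limit leaves unreadable from compound 2 to compound 3 is expected to be none beyond the scatter.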

Compound 3, half-maximal inhibitory concentration: 3400 nM
Compound 3: the middle estimate sits 7.4-fold (0.87 log units) above what was measured, outside the stated range (below it).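

In this assay, the group on the amide-type nitrogen proves able to move the series off its limit: 4-phenylphenyl in place of 4-fluorobenzyl gives an at least 5.8-fold lower number from compound 2 to compound 3 (0.76 log units; beyond the scatter), and 4-phenylphenyl in place of propyl gives an at least 5.8-fold lower number from compound 1 to compound 3 (0.76 log units; beyond the scatter). Compound 3, at 3400 nM, is the only one of the three to carry a number, so both steps are known only as minimum sizes. The other two compounds remain at a limit of the assay, not a number: the limit of > 20000 nM in this assay, at which 2 of the 3 values shown sit.

The change replaces the whole 4-fluorobenzyl group, and the compounds shown do not separate the added aromatic ring from the loss of the saturated carbon attached to the nitrogen. As far as these compounds go, a plain phenyl or a 4-phenylbenzyl group on that nitrogen would bear on this, and how far a carboxylic acid on the outer ring would carry the step remains open.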